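Swapping the Pyridyl Ring: Expected Effect on Receptor Binding

The source may report more compounds than this note shows. Statements on the series, on what has been measured and on what is new or still open speak of the compounds shown alone.

For the measured compounds named here, compound 3 `COc1cc(-c2nc(C(c3ccc(F)cc3)c3ccc(F)cc3)sc2CC(=O)O)ccn1` gives 29 nM in an in vitro assay on HEK385-7 cells for displacement of a labelled ligand from prostaglandin D2 receptor 2 (Homo sapiens) (a higher number here means a weaker inhibitor, a lower number a stronger inhibitor), the highest of the three numbers measured so far. Compound 1 `O=C(O)Cc1sc(C(c2ccc(F)cc2)c2ccc(F)cc2)nc1-c1ccccc1` gives 16 nM, and a 1.8-fold higher number from compound 1 to compound 3 (0.26 log units; within the scatter). Compound 2 `O=C(O)Cc1sc(C(c2ccc(F)cc2)c2ccc(F)cc2)nc1-c1cccc(F)c1` gives 1.4 nM, and a 21-fold higher number from compound 2 to compound 3 (1.32 log units; beyond the scatter); the step of an 11-fold lower number from compound 1 to compound 2 (1.06 log units; beyond the scatter) is the only measured one that introduces a fluorine. Compound 4 `Nc1cc(-c2nc(C(c3ccc(F)cc3)c3ccc(F)cc3)sc2CC(=O)O)cc(F)n1` differs from compound 3 by 2-amino-6-fluoropyridin-4-yl in place of 2-methoxypyridin-4-yl on an aromatic carbon. Going by the values given here, no measured step exchanges one substituted pyridyl ring for another, so the steps of a 1.8-fold higher number from compound 1 to compound 3 (0.26 log units; within the scatter) and a 21-fold higher number from compound 2 to compound 3 (1.32 log units; beyond the scatter) only bracket how much this position can matter. Compound 4 is therefore expected to give 15 nM, with a range from 4 nM to 60 nM. That estimate means an expected step of a 1.9-fold lower number from compound 3 to compound 4 (0.29 log units; within the scatter), modest and uncertain in direction.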

Compound 4, half-maximal inhibitory concentration: 220 nM
Compound 4: the middle estimate sits 15-fold (1.17 log units) below what was measured; measured number above the stated range.
By their numbers in this assay, from the lowest: compound 2; then compounds 1 and 3 (each within the scatter of the next); then compound 4.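

Exchanging one substituted pyridyl ring for another at this position is not neutral: 2-amino-6-fluoropyridin-4-yl in place of 2-methoxypyridin-4-yl gives a clear change (a 7.6-fold higher number from compound 3 to compound 4 (0.88 log units; beyond the scatter)), although both groups hold the same count of heavy atoms. Unlike 2-methoxypyridin-4-yl, which stayed within the scatter of phenyl, this ring also moves beyond the scatter of phenyl (a 14-fold higher number from compound 1 to compound 4 (1.14 log units; beyond the scatter)). Against 3-fluorophenyl the step (a 160-fold higher number from compound 2 to compound 4 (2.20 log units; beyond the scatter)) is the widest listed at this position.

From the compounds shown here alone, whether the amine or the fluoro accounts for the change stays open, as does how a methyl group in either place would read. Nothing given here explains the step.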